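The source may report more compounds than this note shows. Statements on the series, on what has been measured and on what is new or still open speak of the compounds shown alone.

Going by the values given here, compound 2 `NS(=O)(=O)c1ccc2nc(-n3nc(C(F)(F)F)cc3-c3ccc4ccccc4c3)sc2c1` stands lowest of the two numbers measured so far. In a functional assay on the whole organism (strain Wistar albino) for inhibition, with Rattus norvegicus as the target, read by paw edema, with stated times of 30 min and 4 h, at a dose of 50 mg/kg by the oral route (a lower number here means less inhibition, a higher number more inhibition at the dose given (going by the name of the read-out)), compound 2 gives 20%. Its nearest neighbour is compound 1 `NS(=O)(=O)c1ccc2nc(-n3nc(C(F)(F)F)cc3-c3ccc(Cl)cc3)sc2c1`, which in this assay gives 42%. Among the compounds with values here, the only measured step, a number 22 percentage points lower from compound 1 to compound 2 (beyond the scatter), bears directly on the next move, since it is the same naphthalen-2-yl group that now leaves. Compound 3 `NS(=O)(=O)c1ccc2nc(-n3nc(C(F)(F)F)cc3-c3ccccc3)sc2c1` arises from compound 2 by phenyl in place of naphthalen-2-yl on an aromatic carbon. Phenyl lacks the chlorine of 4-chlorophenyl, so compound 1 is only a partial guide, but a return of most of the loss is expected because compound 1 with 4-chlorophenyl gives 42%. The step of a number 15 percentage points higher from compound 2 to compound 3 (beyond the scatter) is therefore expected to run upward, beyond the scatter but short of the full recovery. For compound 3 the estimate in this assay is 35%, within a range from 18% to 52%.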

Compound 3, a percentage reported as inhibition, in the whole organism at one dose (the size of the read-out at that dose, not a potency): 17%
For compound 3 the middle estimate is 18 percentage points above the measured one; the whole stated range lies above it.
By their numbers in this assay, from the lowest: compounds 3 and 2 (each within the scatter of the next); then compound 1.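

In this assay, the switch on this aromatic carbon from naphthalen-2-yl to phenyl gives a number 3 percentage points lower from compound 2 to compound 3 (within the scatter), so removing the second aromatic ring leaves the read-out unchanged within the scatter. The clear difference lies instead in the chloro substituent of the 4-chlorophenyl group, with hydrogen in its place giving a number 25 percentage points lower from compound 1 to compound 3 (beyond the scatter); among these three compounds, only compound 1 stands apart. Nothing available accounts for this difference.

From the compounds shown here alone, it remains open whether the higher read-out is specific to chloro or would also appear with a methoxy, amino or carboxylic acid group on the phenyl ring. Also open, going by these compounds, is whether a fluoro or bromo group in the same place would match compound 1 in this assay.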